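Amide to Sulfonamide: Expected Cytotoxicity of Compound 4

The source may hold more compounds than are shown below. What is called first, only, known or untested is meant among the compounds shown, and "the series" means these compounds.

Compound 3 `Cc1ccc(C(=O)Nc2ncc(C(Oc3ccc4cc(Br)ccc4c3)c3ccc(Cl)cc3)s2)cc1` was tested in an ADME assay on HepG2 2.2.15 cells (Homo sapiens) for cytotoxicity (on this read-out higher numbers stand for lower toxicity in this test and lower numbers for higher toxicity in this test), where compound 3 is recorded as "not toxic" (no number reported) without a number. Compound 1 `O=C(Nc1ncc(Cc2ccc(F)cc2)s1)c1ccccc1` is likewise recorded as "not toxic" (no number reported) in this assay, again with no figure. Compound 2 `Cc1cc(C(C)C)ccc1OC(c1ccc(Cl)cc1)c1cnc(NC(=O)OC(C)(C)C)s1` reaches only a limit of the assay in this assay, > 50000 nM, which is the level described by the limit of > 50000 nM in this assay, at which 1 of the 3 values shown sits. No numbered step between measured compounds exists, so nothing shows how far this series moves in this assay. Compound 4 `O=S(=O)(Nc1ncc(C(Oc2ccc3cc(Br)ccc3c2)c2ccc(Cl)cc2)s1)c1ccc2c(c1)CCO2` differs from compound 3 by a group of 12 heavy atoms (8 carbon, 3 oxygen, 1 sulfur; one five-membered non-aromatic ring with 1 hetero atom, one six-membered aromatic ring of carbon only) in place of a group of 9 heavy atoms (8 carbon, 1 oxygen; one six-membered aromatic ring of carbon only), on a nitrogen on an aromatic ring. Among the measured compounds shown here, with no measured step to lean on, no shift beyond the scatter is expected in this assay. Compound 4 is expected to come out at 50000 nM, most likely again as a limit, within 20000 nM to 100000 nM.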

Compound 4, half-maximal cytotoxic concentration: > 50000 nM
Compound 4: a limit, no number; the forecaster's own chance of this, stated with the estimate: 75%; the middle value lies on the limit itself.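

Compound 3 is recorded without a number and compound 4 only as a limit of the assay, so no step can be read between them. The compounds shown leave open how far any single change moves the values in this assay.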